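The source may hold more compounds than are shown below. What is called first, only, known or untested is meant among the compounds shown, and "the series" means these compounds.

Compound 1 `COc1cc(-c2nn(-c3cccc(NC(=O)Nc4ccc(Cl)c(Cl)c4)c3)cc2-c2ccncc2)ccc1Cl` stands second highest of the three numbers recorded in a functional assay on M14 cells (Homo sapiens) for inhibition, read by sulforhodamine B assay, with a stated time of 48 h (a lower number here means a stronger inhibitor of growth, a higher number a weaker inhibitor of growth), where compound 1 gives 911 nM. Within the data shown here, compound 2 `O=C(Nc1cccc(-n2cc(-c3ccncc3)c(-c3ccc(Cl)c(O)c3)n2)c1)Nc1ccc(Cl)c(Cl)c1` gives 1180 nM, and the only step between compounds differing in a single place is a 1.3-fold higher number from compound 1 to compound 2 (0.11 log units; within the scatter). Compound 3 `O=C(Nc1cccc(-n2cc(-c3ccncc3)c(-c3ccc(Cl)c(O)c3)n2)c1)Nc1cc(C(F)(F)F)cc(C(F)(F)F)c1` gives 607 nM. Compound 4 `COc1cc(-c2nn(-c3cccc(NC(=O)c4ccccc4)c3)cc2-c2ccncc2)ccc1Cl` differs from compound 1 by phenyl in place of (3,4-dichlorophenyl)amino on a carbonyl carbon. Among the measured compounds shown here, no measured step bears on this change: the single known step concerns the group on the ring oxygen and lies within the scatter, so it says nothing about replacing the whole amino-aryl portion at the carbonyl. The step is therefore expected to be a 2.2-fold higher number from compound 1 to compound 4 (0.34 log units; beyond the scatter), with a wide uncertainty. For compound 4 the estimate is 2000 nM, ranging from 500 nM to 8000 nM.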

Compound 4, concentration for 50% growth inhibition: 575 nM
Compound 4: middle estimate off by 3.5-fold (0.54 log units), on the high side; the measured number falls inside the stated range.
By their numbers in this assay, from the lowest: compounds 4, 3, 1 and 2 (each within the scatter of the next, the first and the last beyond it).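

In this assay, the change on the carbonyl carbon gives a 1.6-fold lower number from compound 1 to compound 4 (0.20 log units; within the scatter), the first step shown that alters this part of the molecule rather than the group on the ring oxygen. The whole (3,4-dichlorophenyl)amino group, including its two chlorines and the amide-type nitrogen, can thus give way to phenyl with no change beyond the scatter in this pair. No data shown here account for this result. The compounds shown leave open whether a non-aromatic group on the carbonyl carbon, such as a morpholine ring or a short alkyl chain, would keep this level of growth inhibition. They also leave open whether a substituted phenyl, such as 4-methoxyphenyl, would do so.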